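Aryl amine swap on the shared core: iodide to methoxy

The compounds below may be only part of what the source reports. "The series", "measured", "known", "first", "only" and "open" are said of these compounds alone.

Measured so far:
- compound 1, `O=C1C=C(Nc2ccc(I)cc2)C(=O)c2c1nc1n2[C@H]2OC[C@@H](O)[C@H]2OC1`, 2230 nM
- compound 2, `COc1cccc(NC2=CC(=O)c3c(nc4n3[C@H]3OC[C@@H](O)[C@H]3OC4)C2=O)c1`, 3830 nM
- compound 3, `Cc1ccc(NC2=CC(=O)c3c(nc4n3[C@H]3OC[C@@H](O)[C@H]3OC4)C2=O)cc1C`, 4950 nM

In a functional assay on MCF7 cells (Homo sapiens) for inhibition, read by sulforhodamine B assay (a lower number here means a stronger inhibitor, a higher number a weaker inhibitor), compound 1 gives the lowest of the three numbers; compound 2 sits nearest, and only compound 3 lies beyond the scatter from it. Among the measured compounds shown here, the one step among the measured compounds, a 1.3-fold higher number from compound 2 to compound 3 (0.11 log units; within the scatter), exchanges one aryl group on the amine nitrogen for another and stays within the scatter.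

Compound 4, `COc1cccc(NC2=CC(=O)c3nc4n(c3C2=O)[C@H]2OC[C@@H](O)[C@H]2OC4)c1`, is unmeasured. Its change from compound 1 is 3-methoxyphenyl in place of 4-iodophenyl on an amine nitrogen. For the measured compounds named here, no measured step covers this exact exchange. Compound 2 carries the same 3-methoxyphenyl group on a differently arranged core and gives 3830 nM, close to compound 1. Together with the small effect of the aryl exchange from compound 2 to compound 3, a step of about a 1.6-fold higher number from compound 1 to compound 4 (0.20 log units; within the scatter) is expected, toward a somewhat higher number but not clearly beyond the scatter. Compound 4 is therefore estimated at 3500 nM, with a range of 1500 nM to 8000 nM.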

Compound 4, half-maximal inhibitory concentration: > 4000 nM
Compound 4 gave a limit, no number; the forecaster's own chance of this, stated with the estimate: 5%; middle value at least 1.1-fold (0.05 log units) away from the limit.
By their numbers in this assay, from the lowest: compounds 1, 2 and 3 (each within the scatter of the next, the first and the last beyond it).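

In this assay compound 4 gives > 4000 nM, which is a limit of the assay and not a number. Among the compounds shown here, exchanging 4-iodophenyl for 3-methoxyphenyl on the amine nitrogen gives an at least 1.7-fold higher number from compound 1 to compound 4 (0.25 log units; that floor lies within the scatter), so this exchange now has a first reading on the core of compound 1, but only as a floor, and that floor does not separate the two compounds. The true size of the step remains unknown, and the reading ends where the assay's range ends: the limit of > 4000 nM in this assay, at which 1 of the 4 values shown sits.

Going by these compounds, whether the iodine or the methoxy group matters at this position, or the aryl ring alone, remains open. An unsubstituted phenyl or a short alkyl chain on the same amine nitrogen would test this directly, and a numerical value for compound 4 would settle the size of the step.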